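Working notes: 2,4,6-trifluorophenyl replacing a non-aromatic ring

This account rests on a few compounds, and the source may have more. Where it says the series, first, only, none or still open, it means among the compounds named here.

Within the data shown here, the series so far rests on two compounds measured in an ADME assay on MDBK cells (Bos taurus) for cytotoxicity, read by MTT assay; a higher number here means that more compound is tolerated, a lower number that less compound is tolerated. Compound 1 `OC[C@@H]1[C@@H](O)[C@H](O)[C@@H](O)CN1CCCCCCOc1cc(F)ccc1F` gives > 500000 nM, which is a limit of the assay and not a number. Compound 2 `CCC1CCCCC1OCCCCCCN1C[C@H](O)[C@@H](O)[C@H](O)[C@H]1CO` gives 450000 nM, the only actual number shown, so it cannot yet be ranked against a second number. For compound 1, the evidence stands as the limit of > 500000 nM in this assay, at which 1 of the 2 values shown sits.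

Compound 3 `OC[C@@H]1[C@@H](O)[C@H](O)[C@@H](O)CN1CCCCCCOc1c(F)cc(F)cc1F` is the next to be read. The change is a group of 9 heavy atoms (6 carbon, 3 fluorine; one six-membered aromatic ring of carbon only) in place of a group of 8 heavy atoms (8 carbon; one six-membered non-aromatic ring of carbon only), on an oxygen on a saturated carbon. The 2,4,6-trifluorophenyl group enters on an oxygen on a saturated carbon, so compound 3 again carries a fluorinated aromatic ring, as compound 1 does.

Among the measured compounds shown here, the one measured step bearing on this is an at least 1.1-fold lower number from compound 1 to compound 2 (0.04 log units; that floor lies within the scatter). It exchanged the same kinds of group in the opposite sense, and its floor lies within the scatter. No step beyond the scatter is therefore expected in this assay, although that floor leaves a larger true step open. The expected step is a 1.1-fold higher number from compound 2 to compound 3 (0.05 log units; within the scatter). A report as a limit of the assay is also likely. For compound 3 the estimate is 500000 nM, with an expected range from 250000 nM to 1000000 nM.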

Compound 3, half-maximal cytotoxic concentration: > 500000 nM
Compound 3 was reported as a limit; the forecaster's own chance of this, stated with the estimate: 65%; the middle value sits exactly at the limit.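

In this assay compound 3 gives > 500000 nM, which is a limit of the assay and not a number, so a second fluorinated phenyl group on this oxygen is also reported only as a limit. Exchanging the non-aromatic ring for 2,4,6-trifluorophenyl gives an at least 1.1-fold higher number from compound 2 to compound 3 (0.04 log units; that floor lies within the scatter), so this direction of the exchange, like the reverse one already seen, supports no step beyond the scatter, although a larger true step remains possible. The step between 2,5-difluorophenyl and 2,4,6-trifluorophenyl cannot be read, so the number and placement of the fluorines cannot be compared, and the evidence at this position stands as follows: the limit of > 500000 nM in this assay, at which 2 of the 3 values shown sit.

Going by these compounds, how far the true values of the two fluorinated compounds lie from that limit remains open, so no order can be given between them or a firm size to their steps from the non-aromatic ring. Also open, on these data alone, is what this assay would give for an unsubstituted phenyl ring, for a phenyl ring carrying an amine or a carboxylic acid, or for a longer chain on the shared core.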